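Carbamate series: methoxy in place of chloro

A few compounds are considered here, and "the series" means these few. Any claim that something is new, unique, unknown or untested is made for them only; others in the source may bear on it.

Compound 1 `N#C[Se]c1ccc(NC(=O)Oc2ccccc2)cc1` gives 9100 nM in a functional assay on PC-3 cells (Homo sapiens) for cytotoxicity, read by MTT assay, with a stated time of 72 h; on this read-out higher numbers stand for weaker inhibition of growth and lower numbers for stronger inhibition of growth. Compound 2 `O=C(Nc1ccc([Se][Se]c2ccc(NC(=O)Oc3ccccc3)cc2)cc1)Oc1ccccc1` gives 5300 nM in this assay, and compound 3 `N#C[Se]c1ccc(NC(=O)Oc2ccc(Cl)cc2)cc1` gives 6400 nM. Compound 3 stands second highest of the three numbers, with compound 2 nearest and compound 1 furthest, both within the scatter. Compound 4 `COc1ccc(OC(=O)Nc2ccc([Se]C#N)cc2)cc1` differs from compound 3 as follows: methoxy in place of chloro on an aromatic carbon. Going by the values given here, the only measured step at this place, a 1.4-fold lower number from compound 1 to compound 3 (0.15 log units; within the scatter), lies within the scatter, and no measured step swaps one substituent for another there. A step within the scatter is therefore expected in this assay, in no particular direction. For compound 4 the estimate is 7000 nM, with a range from 3500 nM to 14000 nM. The expected step is a 1.1-fold higher number from compound 3 to compound 4 (0.04 log units; within the scatter).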

Compound 4, concentration for 50% growth inhibition: 7500 nM
Beside the measured number, compound 4's estimate is 1.1-fold (0.03 log units) below it; low and high end bracket the measured number.
By their numbers in this assay, from the lowest: compounds 2, 3, 4 and 1 (each within the scatter of the next).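

Methoxy in place of chloro gives a 1.2-fold higher number from compound 3 to compound 4 (0.07 log units; within the scatter), and methoxy in place of hydrogen gives a 1.2-fold lower number from compound 1 to compound 4 (0.08 log units; within the scatter). In this assay, hydrogen, chloro and methoxy on this aromatic carbon, para to a large group, therefore all lie within the scatter of one another, and the first substituent carrying a hydrogen-bond acceptor here does not separate from the others. No measured evidence bears on this result.

As far as these compounds go, whether an amine, a carboxylic acid or a longer chain at this place would give a step beyond the scatter stays open. From the compounds shown here alone, whether these substituents behave alike on the diselenide of compound 2 also stays open.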